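From Benzyl to Naphthalen-1-yl on the Amide Nitrogen

A few compounds are considered here, and "the series" means these few. Any claim that something is new, unique, unknown or untested is made for them only; others in the source may bear on it.

Of the compounds shown here, two have been measured in a functional assay on THP-1 cells (Homo sapiens) for inhibition; on this read-out higher numbers stand for weaker inhibition and lower numbers for stronger inhibition. Compound 1, `Cc1c(C(=O)N[C@H](C(=O)NC(CC(=O)O)C(=O)CF)C(C)C)n(C)c2ccccc12`, is the weaker of the pair: in this assay compound 1 gives 10000 nM. Compound 2, `C[C@H](NC(=O)C(=O)NCc1ccccc1)C(=O)N[C@@H](CC(=O)O)C(=O)COc1c(F)c(F)cc(F)c1F`, gives 160 nM in this assay, the lowest number of the two, and its gap to compound 1 lies well beyond the scatter of repeated measurements. Going by the values given here, the two compounds differ in many places at once, so no single step between them can be read out.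

Compound 3, `C[C@H](NC(=O)C(=O)Nc1cccc2ccccc12)C(=O)N[C@@H](CC(=O)O)C(=O)COc1c(F)c(F)cc(F)c1F`, has not yet been measured. It differs from compound 2 in one place: naphthalen-1-yl in place of benzyl on an amide-type nitrogen, so that the benzylamino end becomes a (naphthalen-1-yl)amino end. Among the compounds with values here, no measured pair isolates this change. The size of the step can only be estimated. A step of the size given by a 1.6-fold lower number from compound 2 to compound 3 (0.20 log units; within the scatter) is expected, that is, no change beyond the scatter or a modest gain in potency. Compound 3 is therefore estimated to give 100 nM in this assay, with a range from 30 nM to 400 nM.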

Compound 3, half-maximal inhibitory concentration: 60 nM
Beside the measured number, compound 3's estimate is 1.7-fold (0.22 log units) above it; low and high end bracket the measured number.
By their numbers in this assay, from the lowest: compound 3; then compound 2; then compound 1.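

In this assay, putting naphthalen-1-yl in place of benzyl on the amide-type nitrogen gives a 2.7-fold lower number from compound 2 to compound 3 (0.43 log units; beyond the scatter) and so lies beyond the scatter, making this the only single-place change that can be read among these compounds. The position therefore takes a larger all-carbon group, 10 heavy atoms and 2 six-membered aromatic rings where benzyl has 7 heavy atoms and one such ring, with a modest gain rather than a loss of inhibition. No measurement offered here accounts for the size of this step.

The exchange alters the ring count and removes the methylene link of benzyl in a single move, so the compounds shown do not tell which of the two carries the step, and a phenyl group on the same nitrogen would speak to that. As far as these compounds go, how an amine, a carboxylic acid or a longer chain such as 2-phenylethyl would fare on this nitrogen remains open, and the steps from compound 1 to the other two cannot be read, as it differs from them in many places.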